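Cyclopentenone series: cytotoxicity notes before compound 4

The compounds below may be only part of what the source reports. "The series", "measured", "known", "first", "only" and "open" are said of these compounds alone.

Compound 1 `COC(=O)c1cc(C2=C(c3cc(OC)c(OC)c(OC)c3)C(=O)CC2O[SiH2]C(C)(C)C)ccc1OC` carries a 3,4,5-trimethoxyphenyl group and a 4-methoxy-3-(methoxycarbonyl)phenyl group on the shared core. In an ADME assay on KB cells (Homo sapiens) for cytotoxicity, read by MTT assay, with a stated time of 72 h (a higher number here means a weaker inhibitor, a lower number a stronger inhibitor), compound 1 gives only a limit of the assay, > 100 ug/mL, and no number. Compound 3 `COc1ccc(OC)c(C2=C(c3cc(OC)c(OC)c(OC)c3)C(=O)CC2O)c1` in this assay likewise reaches only a limit, > 100 ug/mL. For compound 2 `COc1ccc(C2=C(c3cc(OC)c(OC)c(OC)c3)C(=O)CC2O)cc1` this assay records "not determined" (no result reported), so no value stands for it. Compound 1 therefore stands at the weak end of what is shown, and the picture is summarised by the limit of > 100 ug/mL in this assay, at which 2 of the 3 values shown sit; no step between measured compounds can be drawn from these entries.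

Compound 4 `COc1cc(C2=C(c3ccccc3)C(O[SiH2]C(C)(C)C)CC2=O)cc(OC)c1OC` is the next candidate. The change from compound 1 is phenyl in place of 4-methoxy-3-(methoxycarbonyl)phenyl on a double-bonded ring carbon, with the ester-bearing aryl replaced by a bare phenyl and the silyl ether retained on the core.

With both measured values sitting at a limit, no step beyond the usual scatter is expected in this assay for this change. Compound 4 is expected to remain weak, with an estimated value of 90 ug/mL (range 25 ug/mL to 200 ug/mL). That estimate implies a step of an at least 1.1-fold lower number from compound 1 to compound 4 (0.04 log units; that floor lies within the scatter), expected to be within the scatter and quite possibly again reported only as a limit.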

Compound 4, half-maximal inhibitory concentration: > 100 ug/mL
Compound 4: only a limit was reported; the forecaster's own chance of this, stated with the estimate: 60%; middle value at least 1.1-fold (0.04 log units) from the limit.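

In this assay compound 4 gives > 100 ug/mL, which is a limit of the assay. Within the data shown here, compound 1 also stands at a limit, so no step between compound 1 and compound 4 can be read. The compounds shown leave open whether replacing 4-methoxy-3-(methoxycarbonyl)phenyl with phenyl shifts cytotoxicity at all.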